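Returning to a benzyl group at the bicyclic core

This account rests on a few compounds, and the source may have more. Where it says the series, first, only, none or still open, it means among the compounds named here.

Compound 3 `COc1ccc(F)cc1CNCCCNc1ccnc2cc(Oc3ccc(F)cc3)ccc12` gives 9.28 in a physicochemical assay for acid dissociation, the lowest of the three measured numbers, though its gaps to compound 1 `COc1ccc(F)cc1CNCCCNc1ccnc2cc(Cc3cc(C)cc(C)c3)ccc12` with 9.47 and compound 2 `COc1ccc(F)cc1CNCCCNc1ccnc2cc(Cc3ccc(F)cc3)ccc12` with 9.47 lie within the scatter. Compound 4 `COc1ccc(F)cc1CNCCCNc1ccnc2cc(Cc3cccc(C(F)(F)F)c3)ccc12` differs from compound 3 by 3-(trifluoromethyl)benzyl in place of 4-fluorophenoxy on an aromatic carbon. The steps of a number 0.19 log units lower from compound 1 to compound 3 (within the scatter) and a number 0.19 log units lower from compound 2 to compound 3 (within the scatter) ran from a benzyl group to a phenoxy group, the reverse of the present change, while no change at the digits printed from compound 1 to compound 2 (within the scatter) shows that the substituents on the benzyl ring mattered little. Compound 4 is therefore expected to show a step of a number 0.17 log units higher from compound 3 to compound 4 (within the scatter), a small rise within the scatter. Compound 4 is estimated at 9.45, with a range of 9.2 to 9.7.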

Compound 4, acid dissociation constant: 9.47
Compound 4: the middle estimate sits 0.02 log units below what was measured, and the stated range covers the measured number.
By their numbers in this assay, from the lowest: compounds 3, 1, 2 and 4 (each within the scatter of the next).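

In this assay a third substitution pattern on the benzyl ring at this position gives no change at the digits printed from compound 2 to compound 4 (within the scatter) and no change at the digits printed from compound 1 to compound 4 (within the scatter) as the result. Exchanging 4-fluorophenoxy for 3-(trifluoromethyl)benzyl gives a number 0.19 log units higher from compound 3 to compound 4 (within the scatter) and so does not separate the two kinds of group, and none of the four compounds stands apart from the others. Nothing available explains why these numbers stay so close. The compounds shown leave open whether a benzyl ring carrying an amine or a carboxylic acid would shift the number beyond the scatter.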